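From Acetyl to Benzoyl: A Step Awaiting Measurement

The compounds below may be only part of what the source reports. "The series", "measured", "known", "first", "only" and "open" are said of these compounds alone.

Of the compounds shown here, three have so far been measured in a functional assay on U-251 cells (Homo sapiens) for inhibition, read by sulforhodamine B assay, with a stated time of 48 h; on this read-out higher numbers stand for weaker inhibition of growth and lower numbers for stronger inhibition of growth. Compound 1, with structure `CCOC(=O)C(=Cc1c(-c2ccccc2)[nH]c2ccccc12)C(=O)OCC`, gives 4900 nM. Compound 2, with structure `COc1ccc(-c2[nH]c3ccc(OC)cc3c2/C=C(\C#N)S(=O)(=O)c2ccccc2)cc1`, gives 563 nM. Compound 3, with structure `CC(=O)/C(=C\c1c(-c2ccccc2)[nH]c2ccccc12)S(=O)(=O)c1ccccc1`, gives 1200 nM, which places it second highest of the three numbers: compound 2 sits lower by a step beyond the usual scatter, and compound 1 sits higher by a step that is also beyond the scatter.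

Compound 4, with structure `O=C(/C(=C\c1c(-c2ccccc2)[nH]c2ccccc12)S(=O)(=O)c1ccccc1)c1ccccc1`, has not yet been measured. It differs from compound 3 in one place: phenyl in place of methyl on a carbonyl carbon. Cut one bond further out, the same change reads as acetyl to benzoyl.

Going by the values given here, no measured pair in this set shows that change, so there is no direct precedent for the size of its effect. The step of a 1.3-fold lower number from compound 3 to compound 4 (0.12 log units; within the scatter) is expected to be small, within or only slightly beyond the scatter, with no firm direction. Compound 4 is therefore expected to give about 900 nM in this assay, with a likely range from 300 nM to 3000 nM.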

Compound 4, concentration for 50% growth inhibition: 8600 nM
Estimate against measurement, compound 4: 9.6-fold (0.98 log units) below, outside the stated range (above it).
By their numbers in this assay, from the lowest: compound 2; then compound 3; then compounds 1 and 4 (each within the scatter of the next).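

In this assay, putting phenyl in place of methyl on a carbonyl carbon gives a 7.2-fold higher number from compound 3 to compound 4 (0.86 log units; beyond the scatter), which means weaker inhibition of growth. Going by these compounds alone, this is the first pair in the set that differs in one place, so it is the first direct sign that the group on this carbonyl carbon matters for the read-out, and that a ring there can cost activity rather than leave it unchanged. Nothing measured here accounts for the size of this step.

With only methyl and phenyl compared at this place, a single step cannot show whether the loss belongs to the aromatic ring or comes with any group bigger than methyl. A propyl chain, a cyclohexyl ring or an amine on the same carbonyl carbon would help separate those two readings.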